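Silyl ether in place of formate on the shared core

The compounds below may be only part of what the source reports. "The series", "measured", "known", "first", "only" and "open" are said of these compounds alone.

Three compounds of the series have numbers in a functional assay on MCF7 cells (Homo sapiens) for cytotoxicity, read by sulforhodamine B assay; a higher number here means a weaker inhibitor, a lower number a stronger inhibitor. Compound 1 `C=C1[C@@H](OC(C)=O)C[C@@H]2[C@](C)(COC=O)[C@H](OC(C)=O)CC[C@@]2(C)[C@@H]1C[C@@H](Nc1ccc(Br)cc1)C1=CCOC1=O` gives 11400 nM, compound 2 `C=C1[C@@H](OC(C)=O)C[C@@H]2[C@](C)(COC=O)[C@H](OC(C)=O)CC[C@@]2(C)[C@@H]1C[C@@H](Nc1ccccc1C(=O)O)C1=CCOC1=O` gives 30800 nM, and compound 3 `C=C1[C@@H](OC(C)=O)C[C@@H]2[C@](C)(COC=O)[C@H](OC(C)=O)CC[C@@]2(C)[C@@H]1C[C@@H](Nc1ccc(O)cc1)C1=CCOC1=O` gives 18100 nM. Compound 1 holds the lowest of the three numbers: a 1.6-fold higher number from compound 1 to compound 3 (0.20 log units; within the scatter), while a 2.7-fold higher number from compound 1 to compound 2 (0.43 log units; beyond the scatter). Between the other two, a 1.7-fold lower number from compound 2 to compound 3 (0.23 log units; within the scatter).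

Compound 4 `C=C1[C@@H](OC(C)=O)C[C@@H]2[C@](C)(CO[Si](C)(C)C(C)(C)C)[C@H](OC(C)=O)CC[C@@]2(C)[C@@H]1C[C@@H](Nc1ccc(Br)cc1)C1=CCOC1=O` differs from compound 1 in one place: a group of 7 heavy atoms (6 carbon, 1 silicon; no ring) in place of a group of 2 heavy atoms (1 carbon, 1 oxygen; no ring), on an oxygen on a saturated carbon. Every measured step changes the group on the amine nitrogen and leaves the oxygen on the saturated carbon untouched, so none of them bears directly on this change. For the measured compounds named here, the only guidance is the narrow spread of the series as a whole, in which the largest step, a 2.7-fold higher number from compound 1 to compound 2 (0.43 log units; beyond the scatter), is only modest. Compound 4 is therefore expected to show no change at the digits printed from compound 1 to compound 4 (within the scatter). Going by the values given here, the estimate for compound 4 is 11400 nM, in a range from 4000 nM to 32000 nM, the width reflecting that no measured step tests this position.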

Compound 4, half-maximal inhibitory concentration: 3920 nM
The estimate for compound 4 lay 2.9-fold (0.46 log units) above the measured number, and the stated range ends above it.
By their numbers in this assay, from the lowest: compound 4; then compounds 1, 3 and 2 (each within the scatter of the next, the first and the last beyond it).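

In this assay, the oxygen on a saturated carbon is not a silent position: with the amine group held as in compound 1, replacing formyl with the 7-atom silicon-bearing group gives a 2.9-fold lower number from compound 1 to compound 4 (0.46 log units; beyond the scatter). The step is modest, but it shows that this part of the shared core can take a much bigger group, with 6 carbons and 1 silicon, without the number rising. For the compounds shown here, its direction is opposite to the one step from compound 1 on the amine nitrogen that lies beyond the scatter, a 2.7-fold higher number from compound 1 to compound 2 (0.43 log units; beyond the scatter). No measurement available here explains the shift.

Going by these compounds, it remains open whether the lower number follows the silicon or simply the larger group, which a benzyl or trimethylsilyl group on the same oxygen would help separate. Also open, on these data alone, is whether the same shift holds with the 2-carboxyphenyl and 4-hydroxyphenyl groups on the amine nitrogen.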